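Bromo substitution across two sulfonamide hydrazone cores

The source may report more compounds than this note shows. Statements on the series, on what has been measured and on what is new or still open speak of the compounds shown alone.

Compound 1 `NS(=O)(=O)c1ccc(C(=O)N/N=C(/CS(=O)(=O)c2ccccc2)c2ccccc2)cc1` and compound 2 `NS(=O)(=O)c1ccc(C(=O)N/N=C(/CS(=O)(=O)c2ccccc2)c2ccc(Br)cc2)cc1` share a core; in a functional assay on MCF7 cells (Homo sapiens) for antiproliferative activity, read by MTT assay (on this read-out lower numbers stand for stronger inhibition and higher numbers for weaker inhibition), compound 1 gives 10700 nM and compound 2 gives 19100 nM. The change between them is bromo in place of hydrogen on an aromatic carbon and it made a step of a 1.8-fold higher number from compound 1 to compound 2 (0.25 log units; within the scatter). Compound 3 `NS(=O)(=O)c1ccc(C(=O)N/N=C\c2ccccc2)cc1` has a different core; the difference between the two cores is not broken down here. In this assay compound 3 gives 14900 nM. Compound 4 `NS(=O)(=O)c1ccc(C(=O)N/N=C\c2ccc(Br)cc2)cc1` is not yet measured; it differs from compound 3 by bromo in place of hydrogen on an aromatic carbon, the same change as from compound 1 to compound 2, at a place described in the same words. Since that change gave a 1.8-fold higher number from compound 1 to compound 2 (0.25 log units; within the scatter), compound 4 is expected to lie near compound 3, with an expected step of a 1.3-fold higher number from compound 3 to compound 4 (0.13 log units; within the scatter). Compound 4 is estimated at 20000 nM, between 10000 nM and 40000 nM.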

Compound 4, half-maximal inhibitory concentration: 1370 nM
For compound 4 the middle estimate is 15-fold (1.16 log units) above the measured one; the whole stated range lies above it.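

In this assay the change from phenyl to 4-bromophenyl did not carry over from one core to the other, the new step being an 11-fold lower number from compound 3 to compound 4 (1.04 log units; beyond the scatter). The two steps differ: the same change on two cores in this assay, a 1.8-fold higher number (0.25 log units; within the scatter) from compound 1 to compound 2 and an 11-fold lower number (1.04 log units; beyond the scatter) from compound 3 to compound 4, 19-fold (1.29 log units) apart, beyond the scatter of two such steps. In this series, then, the step on the core of compound 1 gave no reliable guide to the step on the core of compound 3, but with one pair per core this does not show which feature of the cores sets the steps apart, and it gives no rule for any further core.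

The compounds shown leave open whether the large step is peculiar to bromo. An amine or a carboxylic acid in the same place on the core of compound 3 would test this.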